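A few compounds are considered here, and "the series" means these few. Any claim that something is new, unique, unknown or untested is made for them only; others in the source may bear on it.

In a functional assay on the whole organism with Mus musculus as the target, in the maximal electroshock model (on this read-out lower numbers stand for an effect already at smaller amounts and higher numbers for an effect only at larger amounts of compound), compound 2 `CCCC(=O)OC1CCN(c2ccc(-c3ccccc3Cl)nn2)CC1` gives 28 mg/kg, within the scatter of compound 3 `CCCC(=O)OC1CCN(c2ccc(-c3ccc(Cl)cc3Cl)nn2)CC1` at 50 mg/kg, whereas compound 1 `O=[N+]([O-])c1cccc(-c2ccc(N3CCC(O)CC3)nn2)c1` gives 79 mg/kg. Compound 4 `CNC(=O)OC1CCN(c2ccc(-c3ccccc3Cl)nn2)CC1` differs from compound 2 by methylamino in place of propyl on a carbonyl carbon. Among the measured compounds shown here, the only measured step, a 1.8-fold higher number from compound 2 to compound 3 (0.25 log units; within the scatter), is chloro in place of hydrogen on an aromatic carbon. For the measured compounds named here, it concerns a different place and offers little guidance here, and no measured pair changes this group. As far as these compounds go, no step beyond the scatter is therefore expected in this assay, and the direction remains open. The expected step is a 1.3-fold higher number from compound 2 to compound 4 (0.10 log units; within the scatter). For compound 4 the estimate is 35 mg/kg, with an expected range from 14 mg/kg to 90 mg/kg.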

Compound 4, dose for half-maximal effect: 10 mg/kg
Estimate against measurement, compound 4: 3.5-fold (0.54 log units) above; the whole stated range lies above it.
By their numbers in this assay, from the lowest: compound 4; then compounds 2, 3 and 1 (each within the scatter of the next, the first and the last beyond it).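

In this assay, replacing propyl with methylamino on this carbonyl carbon gives a 2.8-fold lower number from compound 2 to compound 4 (0.45 log units; beyond the scatter), showing that this position affects the read-out, which the chloro step elsewhere on the molecule could not show. The change from (propylcarbonyl)oxy to (methylcarbamoyl)oxy is tolerated here, but this single pair cannot separate the effect of the entering nitrogen and its hydrogen-bond donor from the loss of carbon.

As far as these compounds go, whether ethylamino or dimethylamino at this carbonyl carbon would follow the same step remains open, as does whether the step carries over to the core of compound 3. No evidence at hand bears on the cause of this step.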